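Hydroxyalkyl and cycloalkyl amines on a shared triazolopyrimidine core

The source may hold more compounds than are shown below. What is called first, only, known or untested is meant among the compounds shown, and "the series" means these compounds.

Measured so far in an assay on isolated protein for binding affinity to adenosine receptor A1 (Bos taurus); a lower number here means a stronger inhibitor, a higher number a weaker inhibitor:
compound 1 `OC1CCC(Nc2nc(-c3ccccc3)nc3c2nnn3Cc2ccccc2Cl)CC1` gives 3100000 nM
compound 2 `OCCNc1nc(-c2ccccc2)nc2c1nnn2Cc1ccccc1Cl` gives 116000000 nM
compound 3 `Clc1ccccc1Cn1nnc2c(NC3CCC3)nc(-c3ccccc3)nc21` gives 24000000 nM

Compound 3 holds the second highest number of the three in this assay: from compound 1 it is reached by a 7.7-fold higher number from compound 1 to compound 3 (0.89 log units; beyond the scatter), and from compound 2 by a 4.8-fold lower number from compound 2 to compound 3 (0.68 log units; beyond the scatter). The full spread of the set is a 37-fold higher number from compound 1 to compound 2 (1.57 log units; beyond the scatter).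

Compound 4 `CC(O)CNc1nc(-c2ccccc2)nc2c1nnn2Cc1ccccc1Cl` is not yet measured. Against compound 3 the change is 2-hydroxypropyl in place of cyclobutyl on a nitrogen on an aromatic ring. Going by the values given here, the step bearing most directly on it is the one from compound 2 to compound 3, where the acyclic hydroxyalkyl amine gave the higher number; compound 4 returns to an acyclic hydroxyalkyl amine of the same atom count as the ring it replaces, so a step back toward the number of compound 2 is expected in this assay, modest in size and upward. Compound 1 shows that a hydroxyl-bearing substituent can also sit at the low end of this set, so the expectation is held loosely.

The step from compound 3 to compound 4 is estimated as a 2.5-fold higher number from compound 3 to compound 4 (0.40 log units; beyond the scatter). For compound 4 the expected value in this assay is 60000000 nM, with a range of 15000000 nM to 250000000 nM.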

Compound 4, inhibition constant: 32000000 nM
Estimate against measurement, compound 4: 1.9-fold (0.27 log units) above, and the stated range covers the measured number.
By their numbers in this assay, from the lowest: compound 1; then compounds 3 and 4 (each within the scatter of the next); then compound 2.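

In this assay, 2-hydroxypropyl in place of cyclobutyl on a nitrogen on an aromatic ring gives a 1.3-fold higher number from compound 3 to compound 4 (0.12 log units; within the scatter), so this position does not separate the two groups here, even though one has a four-membered ring and no hydrogen-bond donor and the other has no ring and one donor. Methyl in place of hydrogen on the chain of compound 2 gives a 3.6-fold lower number from compound 2 to compound 4 (0.56 log units; beyond the scatter), which shows that a change this small within the hydroxyalkyl chains can move the number beyond the scatter, while a 10-fold higher number from compound 1 to compound 4 (1.01 log units; beyond the scatter) keeps the 4-hydroxycyclohexyl group of compound 1 apart from the acyclic 2-hydroxypropyl group. No measurement in hand bears on the reason for these differences.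

The compounds shown leave open whether the low number of compound 1 goes with its ring or with its hydroxyl, and a plain cyclohexyl group on the same nitrogen would separate the two. Also open, as far as these compounds go, is whether the hydroxyl matters on the acyclic chains at all, which a propyl group or a longer chain such as 3-hydroxypropyl would test.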